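Chain Lengthening on the Shared Core: Inhibition in Rat Brain

The compounds below may be only part of what the source reports. "The series", "measured", "known", "first", "only" and "open" are said of these compounds alone.

Measured so far in a functional assay on brain (Rattus norvegicus, strain Wistar) for inhibition; on this read-out higher numbers stand for weaker inhibition and lower numbers for stronger inhibition:
compound 1, `CCCCOc1ccc(-c2c(C)[nH]c(=O)n2C)cc1`, gives 5100 nM;
compound 2, `CCCCCCOc1ccc(-c2c(C)[nH]c(=O)n2C)cc1`, gives 7300 nM;
compound 3, `CCCCCCCCc1ccc(-c2c(C)[nH]c(=O)n2C)cc1`, gives 19400 nM.

Compound 2 arises from compound 1 by the change (ethyl in place of hydrogen on a saturated chain carbon, four bonds along the chain from an oxygen on an aromatic ring), and this step, a 1.4-fold higher number from compound 1 to compound 2 (0.16 log units; within the scatter), is within the scatter. Compound 3 differs from compound 1 in more than one place, and the difference between the two cores is not broken down here. In this assay compound 3 stands beyond the scatter from both compound 1 and compound 2, with the weaker inhibition of the three.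

Compound 4, `CCCCCCCCCCc1ccc(-c2c(C)[nH]c(=O)n2C)cc1`, has not been measured. It arises from compound 3 by ethyl in place of hydrogen on a saturated chain carbon, eight bonds along the chain from an aromatic carbon, the same kind of change as from compound 1 to compound 2, though the place differs: four bonds along the chain from an oxygen on an aromatic ring in the one case, eight bonds along the chain from an aromatic carbon in the other. A step of about a 1.4-fold higher number from compound 3 to compound 4 (0.16 log units; within the scatter) is expected from compound 3 to compound 4 in this assay, because the earlier step of a 1.4-fold higher number from compound 1 to compound 2 (0.16 log units; within the scatter) was small. Compound 4 is thus estimated at 28000 nM. The range for compound 4 is estimated to run from 12000 nM to 70000 nM.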

Compound 4, half-maximal inhibitory concentration: 7900 nM
Estimate against measurement, compound 4: 3.5-fold (0.55 log units) above; the whole stated range lies above it.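

In this assay, the new measurement gives a 2.5-fold lower number from compound 3 to compound 4 (0.39 log units; beyond the scatter), so on this core the added ethyl goes with stronger inhibition. The change therefore does not carry over unaltered from one core to the other, and the result on the core of compound 1 was no reliable guide to the result on the core of compound 3: the same change on two cores in this assay, a 1.4-fold higher number (0.16 log units; within the scatter) from compound 1 to compound 2 and a 2.5-fold lower number (0.39 log units; beyond the scatter) from compound 3 to compound 4, 3.5-fold (0.55 log units) apart, beyond the scatter of two such steps This does not show why the two steps differ: the change sits four bonds along the chain from an oxygen on an aromatic ring in one pair and eight bonds along the chain from an aromatic carbon in the other, and a single step on each core cannot separate the place of the change from the core itself.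

The compounds shown leave open whether a longer chain on either core would follow the step seen on its own core. They also leave open how an amine or a carboxylic acid at the end of the chain would read out here.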